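Benzyl-position variation on a hydroxamic acid series

The compounds below may be only part of what the source reports. "The series", "measured", "known", "first", "only" and "open" are said of these compounds alone.

Measured so far:
compound 1 `NCc1ccc(C(=O)NO)cc1`: 695 nM
compound 2 `O=C(NO)c1ccc(Cn2nnc(Cc3ccccn3)n2)cc1`: 25 nM
compound 3 `CC(=O)Nc1ccc(C(=O)NO)cc1`: 270 nM

In an assay on Sf9 cells for inhibition of protein deacetylase HDAC6 (Homo sapiens), read by fluorescence (on this read-out lower numbers stand for stronger inhibition and higher numbers for weaker inhibition), compound 1 gives the highest number of the three. The nearest measured neighbour is compound 3: the step of a 2.6-fold lower number from compound 1 to compound 3 (0.41 log units; beyond the scatter) is modest but beyond the scatter. Among the compounds with values here, compound 2, which carries a substituted tetrazolylmethyl group on the shared core, gives 25 nM in this assay against 695 nM for compound 1; no single-change step connects the two.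

Compound 4 `O=C(NO)c1ccc(Cc2nnc[nH]2)cc1` has not been measured in this assay. The change from compound 1 is 4H-1,2,4-triazol-3-yl in place of amino on a saturated chain carbon bound to an aromatic carbon. Within the data shown here, no measured step covers this change directly. Among the measured compounds shown here, the only single-change step, a 2.6-fold lower number from compound 1 to compound 3 (0.41 log units; beyond the scatter), shows that replacing the amine of compound 1 is tolerated and improves the number somewhat, and compound 2 shows that a five-membered heteroaromatic ring at the saturated carbon is compatible with a low number. An improvement is therefore expected, though smaller than that seen for compound 2; the step from compound 1 is estimated at a 5.8-fold lower number from compound 1 to compound 4 (0.76 log units; beyond the scatter). Compound 4 is expected to give about 120 nM in this assay, plausibly between 35 nM and 400 nM.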

Compound 4, half-maximal inhibitory concentration: 198 nM
Beside the measured number, compound 4's estimate is 1.7-fold (0.22 log units) below it; the measured number falls inside the stated range.
By their numbers in this assay, from the lowest: compound 2; then compounds 4 and 3 (each within the scatter of the next); then compound 1.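

In this assay, the saturated chain carbon of compound 1 can be kept while the amino group is exchanged for 4H-1,2,4-triazol-3-yl, giving a 3.5-fold lower number from compound 1 to compound 4 (0.55 log units; beyond the scatter). Within the data shown here, the earlier single-change step replaced the whole aminomethyl group on the aromatic carbon, so this is the first reading of a change at the amino group alone, and it shows that a five-membered aromatic ring with 3 hetero atoms is accepted there in place of one nitrogen atom. Nothing on hand explains the size of this modest step.

Still open, on these data alone, is whether the gain comes from the triazole ring itself or from the loss of the amino group, which a carboxylic acid or a simple methyl group on the same carbon could separate. Also open, as far as these compounds go, is how a longer chain carrying the same ring, or a substituent on the triazole, would move the number.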